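A few compounds are considered here, and "the series" means these few. Any claim that something is new, unique, unknown or untested is made for them only; others in the source may bear on it.

Measured so far:
compound 1, `CN1CCC[C@@H]1[C@@H]1COc2ccc(O)cc2O1`, 3000 nM
compound 2, `Oc1ccc2c(c1)O[C@H]([C@H]1CCCN1)CO2`, 1300 nM

Both numbers come from an assay on Cerebral cortex (strain Sprague-Dawley) for displacement of a labelled ligand from Neuronal acetylcholine receptor; alpha4/beta2 (Rattus norvegicus); a higher number here means a weaker inhibitor, a lower number a stronger inhibitor. Compound 2 has the lowest of the two numbers; the nearest is compound 1, and the step of a 2.3-fold lower number from compound 1 to compound 2 (0.36 log units; beyond the scatter) lies beyond the scatter, so compound 2 stands as the stronger binder of the pair on this evidence.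

Compound 3, `Oc1ccc2c(c1)O[C@@H]([C@H]1CCCN1)CO2`, is the next compound. Its difference from compound 2 is the two compounds have the same atoms and bonds and differ only in configuration as drawn: 1 of 2 stereo elements differ; a stereocentre at a saturated ring carbon is drawn R in compound 2 and S in compound 3. Nothing has changed in the atoms or bonds; only the spatial arrangement at one ring carbon is inverted.

Among the compounds with values here, neither measured step bears on this change: the one step in hand, a 2.3-fold lower number from compound 1 to compound 2 (0.36 log units; beyond the scatter), concerns a methyl on the amine nitrogen, not configuration. There is therefore no measured guide to how a flipped stereocentre shifts the number in this assay, and the expectation must stay wide. It seems plausible that compound 3 is expected to give a somewhat higher number than compound 2, a step of a 2.3-fold higher number from compound 2 to compound 3 (0.36 log units; beyond the scatter). Compound 3 is estimated at 3000 nM, with a range from 600 nM to 15000 nM.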

Compound 3, inhibition constant: 18000 nM
For compound 3 the middle estimate is 6.0-fold (0.78 log units) below the measured one, outside the stated range (above it).
By their numbers in this assay, from the lowest: compound 2; then compound 1; then compound 3.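

In this assay, the saturated ring carbon whose drawing changes from R to S proves highly sensitive to configuration alone, something the earlier pair could not show, as its compounds share the same configuration. The inversion gives a 14-fold higher number from compound 2 to compound 3 (1.14 log units; beyond the scatter), a much larger change than the removal of methyl from the amine nitrogen, which gave a 2.3-fold lower number from compound 1 to compound 2 (0.36 log units; beyond the scatter), so in this small set the arrangement at this carbon moves the number more than that methyl does. The loss of binding strength can be assigned to this one stereocentre, and not to any change of group, because nothing else separates the pair: the fact that compounds 2 and 3 differ only in the configuration as drawn

The compounds shown leave open whether methyl on the amine nitrogen would have the same modest effect with this carbon drawn S, and whether inverting the other stereo element would matter as much as inverting this one. They also do not say how a larger group on that nitrogen, such as an ethyl group, would change the number with either configuration.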